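Carboxylic Acid in Place of a tert-Butyl Amide

The source may report more compounds than this note shows. Statements on the series, on what has been measured and on what is new or still open speak of the compounds shown alone.

Compound 1 `C=CC1=C(C(=O)NCc2ccc(Cl)cc2)C(c2ccc(OC)c(OC)c2)OC1`: in a functional assay on SW480 cells (Homo sapiens) for cytotoxicity, read by MTT assay, with a stated time of 24 h (on this read-out higher numbers stand for weaker inhibition and lower numbers for stronger inhibition), compound 1 reaches only the assay limit > 100000 nM.
Compound 2 `C=CC1=C(C(=O)NC(C)(C)C)C(c2ccc(OC)cc2)OC1`: in this assay compound 2 likewise gives only the limit > 100000 nM.
Compound 3 `C=CC1=C(C(=O)O)C(c2ccc(Cl)c(Cl)c2)OC1`: in this assay compound 3 also stops at the limit > 100000 nM.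

Compound 2 therefore stands nowhere distinct on the numbers shown: every value is a limit rather than a measured number, as summarised by the limit of > 100000 nM in this assay, at which 3 of the 3 values shown sit. Among the compounds with values here, no step between two measured compounds has been worked out, so nothing quantitative connects them.

Compound 4 `C=CC1=C(C(=O)O)C(c2ccc(OC)cc2)OC1` is the next compound to be tested. Relative to compound 2 the change is hydroxy in place of (tert-butyl)amino on a carbonyl carbon. Compound 3 carries the same carboxy group on the shared core and, in this assay, compound 3 shows only the limit > 100000 nM. Against that background, the step from the amide to the acid is expected to bring no change beyond the scatter, and the estimated step is a step that the limit leaves unreadable from compound 2 to compound 4. Compound 4 is accordingly expected to give about 150000 nM, within a range from 50000 nM to 500000 nM, most likely again as a limit.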

Compound 4, half-maximal inhibitory concentration: > 100000 nM
Compound 4 ended at the assay's limit; the forecaster's own chance of this, stated with the estimate: 85%; the middle value does not contradict the limit.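

Compound 2 and compound 4 both stop at a limit rather than a measured number, so no step can be read for hydroxy in place of (tert-butyl)amino in this assay: the limit of > 100000 nM in this assay, at which 4 of the 4 values shown sit.

The compounds shown leave open whether any group on the shared core can bring a readable cytotoxic effect.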